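Bromo to iodo swap on the shared core

A few compounds are considered here, and "the series" means these few. Any claim that something is new, unique, unknown or untested is made for them only; others in the source may bear on it.

Values in a functional assay on Vero cells (Chlorocebus sabaeus) for cytotoxicity; a lower number here means a stronger inhibitor, a higher number a weaker inhibitor:
- Compound 1 `O=C1NC(O)C(F)=CN1[C@H]1C=C[C@@H](CO)O1`: 7900 nM
- Compound 2 `Nc1nc(=O)n([C@H]2C=C[C@@H](CO)O2)cc1Br`: > 100000 nM

Going by the values given here, compound 1 is the only one of the pair with a number, at 7900 nM. Compound 2 has no number: its reading of > 100000 nM is a limit of the assay. Among the compounds with values here, that is the only position known for compound 2, and the set holds one such reading: the limit of > 100000 nM in this assay, at which 1 of the 2 values shown sits. Within the data shown here, no measured pair here differs in one place, so the data give no direct guide to the next change.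

Compound 3 `Nc1nc(=O)n([C@H]2C=C[C@@H](CO)O2)cc1I` differs from compound 2 by iodo in place of bromo on an aromatic carbon, ortho to an amino group (iodo in place of bromo on an aromatic carbon). In this assay no step beyond the usual scatter is expected, and no direction is favoured. This expectation rests on compound 2 at > 100000 nM, and that reading remains a limit. The estimated move is a number no higher from compound 2 to compound 3 (the limit leaves the size open). Compound 3 is expected to give about 100000 nM, with an estimated range of 40000 nM to 200000 nM. A report as a limit alone is the likeliest outcome.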

Compound 3, half-maximal inhibitory concentration: > 100000 nM
Compound 3: no number, only a limit; the forecaster's own chance of this, stated with the estimate: 70%; the middle value lies on the limit itself.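

Compound 2 and compound 3 both stand only as limits in this assay, not as numbers, and no step can be read between them: the limit of > 100000 nM in this assay, at which 2 of the 3 values shown sit.

The compounds shown leave open where compound 2 and compound 3 truly lie, and whether iodo in place of bromo on an aromatic carbon shifts the reading at all.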